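The source may report more compounds than this note shows. Statements on the series, on what has been measured and on what is new or still open speak of the compounds shown alone.

Of the compounds shown here, three have been read in an ADME assay on BHK cells (Mesocricetus auratus) for cytotoxicity, read by MTT assay, with a stated time of 96 h; on this read-out lower numbers stand for higher toxicity in this test and higher numbers for lower toxicity in this test. Compound 1 (`FC(F)(F)c1cccc(NC(=S)Nc2ccc(I)cc2)c1`) gives 9400 nM, compound 2 (`N#Cc1ccc(NC(=S)Nc2cccc(C(F)(F)F)c2)cc1`) gives 9500 nM and compound 3 (`O=C(NC(=S)Nc1cccc(C(F)(F)F)c1)[C@H]1C[C@@H]2CC[C@H]1C2`) gives 9600 nM. Compound 2 therefore stands among three numbers that lie within the scatter of one another, and no order can be read from them.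

Compound 4 (`CCOC(=O)c1ccc(NC(=S)Nc2cccc(C(F)(F)F)c2)cc1`) has not yet been measured. It keeps the rest of compound 2 and changes one group: ethoxycarbonyl in place of cyano on an aromatic carbon. In words, this is ethoxycarbonyl in place of cyano on an aromatic carbon.

Among the measured compounds shown here, only one measured step bears directly on this change. It is a 1.0-fold higher number from compound 1 to compound 2 (0.00 log units; within the scatter), cyano in place of iodo on an aromatic carbon, and it stays within the scatter. Compound 3 adds indirect support, since its structure is further removed and its value of 9600 nM is still within the scatter of the other two. For the measured compounds named here, no ethoxycarbonyl group has yet been tested, so this support is limited.

In this assay, the expected change is none beyond the scatter, with an estimated no change at the digits printed from compound 2 to compound 4 (within the scatter). For compound 4 the estimate is 9500 nM, with an expected range from 5000 nM to 18000 nM.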

Compound 4, half-maximal cytotoxic concentration: 50000 nM
Beside the measured number, compound 4's estimate is 5.3-fold (0.72 log units) below it; the measured number lies above the stated range.
By their numbers in this assay, from the lowest: compounds 1, 2 and 3 (each within the scatter of the next); then compound 4.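

The position that seemed indifferent when cyano replaced iodo, with a 1.0-fold higher number from compound 1 to compound 2 (0.00 log units; within the scatter), does respond to the group it carries. In this assay, ethoxycarbonyl in place of cyano gives a 5.3-fold higher number from compound 2 to compound 4 (0.72 log units; beyond the scatter), and ethoxycarbonyl in place of iodo gives a 5.3-fold higher number from compound 1 to compound 4 (0.73 log units; beyond the scatter), so the shift appears against both earlier groups at this position and does not depend on which one serves as the reference. Nothing shown here accounts for why ethoxycarbonyl separates from cyano and iodo.

The compounds shown leave open whether a carboxylic acid, a methyl ester or a primary amide at this position would read like compound 4 or stay with compound 2 . They also leave open whether a longer alkoxy chain on the carbonyl would take the number further, and whether the same change would give a similar step if the trifluoromethyl group, kept in all of these compounds, were replaced by a chloro or methoxy group.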